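Removing the Chloro Group Between Two Ring Nitrogens

A few compounds are considered here, and "the series" means these few. Any claim that something is new, unique, unknown or untested is made for them only; others in the source may bear on it.

In a functional assay on IGROV-1 cells (Homo sapiens) for cytotoxicity, read by sulforhodamine B assay, with a stated time of 48 h (on this read-out higher numbers stand for lower toxicity in this test and lower numbers for higher toxicity in this test), compound 1 `ClCc1ccc(Cn2cnc3nc(Cl)nc(Cl)c32)cc1` gives 5750 nM. Compound 3 `ClCc1ccccc1Cn1cnc2nc(Cl)nc(Cl)c21` has a core that differs from that of compound 1 in a way not broken down here; in this assay compound 3 gives 9540 nM. For compound 2 `ClCc1ccccc1Cn1cnc2ncnc(Cl)c21` this assay reports only a limit, > 100000 nM. The step of an at least 10-fold higher number from compound 3 to compound 2 (1.02 log units; beyond the scatter) goes with the change (hydrogen in place of chloro on an aromatic carbon), and its stated size rests on (the limit of > 100000 nM in this assay, at which 1 of the 3 values shown sits). Compound 4 `ClCc1ccc(Cn2cnc3ncnc(Cl)c32)cc1` has not yet been measured in this assay; it differs from compound 1 by the same change, (hydrogen in place of chloro on an aromatic carbon). Because the step of an at least 10-fold higher number from compound 3 to compound 2 (1.02 log units; beyond the scatter) reached the limit of this assay, compound 4 is expected to show a step of a 17-fold higher number from compound 1 to compound 4 (1.24 log units; beyond the scatter) from compound 1. In this assay compound 4 is therefore estimated at 100000 nM, within 30000 nM to 300000 nM, most likely reported as a limit.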

Compound 4, concentration lethal to 50% of the cells: > 100000 nM
Compound 4: no number, only a limit; the forecaster's own chance of this, stated with the estimate: 70%; the middle value lies on the limit itself.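

In this assay, hydrogen in place of the chloro group between two ring nitrogen atoms gives an at least 17-fold higher number from compound 1 to compound 4 (1.24 log units; beyond the scatter), and the change points the same way on both cores: the same change on two cores in this assay, an at least 10-fold higher number (1.02 log units; beyond the scatter) from compound 3 to compound 2 and an at least 17-fold higher number (1.24 log units; beyond the scatter) from compound 1 to compound 4; the limit leaves it open whether they differ

Compound 4 is reported only as a limit, > 100000 nM. The direction therefore carries from one core to the other in these two pairs, but the size of the step on each core stays unknown, and the two sizes cannot be compared: the limit of > 100000 nM in this assay, at which 2 of the 4 values shown sit.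

The compounds shown leave open how an amine or a methoxy group in that same place would read in this assay. As far as these compounds go, all four compounds keep the other chloro group on that ring, so the effect of replacing it with an amine also remains open.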